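This account rests on a few compounds, and the source may have more. Where it says the series, first, only, none or still open, it means among the compounds named here.

Measured compounds in an ADME assay on MT4 cells (Homo sapiens) for cytotoxicity, read by MTT assay; a lower number here means that less compound is tolerated, a higher number that more compound is tolerated:

Compound 1, `COc1cccc2c1c(C(=O)/C=C(\O)C(=O)O)cn2Cc1cccc(F)c1`, gives 65800 nM.
Compound 2, `CCOC(=O)/C(O)=C/C(=O)c1cn(Cc2ccc(F)c(F)c2F)c2cccc(OC)c12`, gives 42700 nM.

Notes on the series. Within the data shown here, of the two numbers in this assay, the one for compound 1 is the higher, but its nearest neighbour is compound 2 and the gap between them lies within the scatter, so the two compounds are not separated by the data. Among the measured compounds shown here, both share the same core, and compound 2 differs from compound 1 in more than one place, so no single step between measured compounds can be read off.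

Compound 3, `COc1cccc2c1c(C(=O)/C=C(\O)C(=O)O)cn2Cc1c(F)ccc(F)c1F`, has not yet been measured. It differs from compound 1 at one place: 2,3,6-trifluorophenyl in place of 3-fluorophenyl on a saturated chain carbon bound to an aromatic nitrogen. For the measured compounds named here, no measured pair isolates this change, so the expectation rests on the two values at hand, which lie close together. In this assay no step beyond the scatter is expected in either direction. Compound 3 is therefore expected near 52000 nM, within a range of 22000 nM to 120000 nM. The expected step of a 1.3-fold lower number from compound 1 to compound 3 (0.10 log units; within the scatter) is estimated to stay within the scatter.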

Compound 3, half-maximal cytotoxic concentration: 49400 nM
The estimate for compound 3 lay 1.1-fold (0.02 log units) above the measured number, and the stated range covers the measured number.
By their numbers in this assay, from the lowest: compounds 2, 3 and 1 (each within the scatter of the next).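

In this assay, among these compounds, 2,3,6-trifluorophenyl in place of 3-fluorophenyl on a saturated chain carbon bound to an aromatic nitrogen gives a 1.3-fold lower number from compound 1 to compound 3 (0.12 log units; within the scatter), which is the first step that isolates a single place. Among the compounds shown here, for this pair, the change of fluorinated phenyl group at this position therefore produces no difference that can be separated from the scatter of repeated measurements, which the earlier compounds, differing in more than one place, could not show. No measured information bears on why the two numbers stay so close, so the result stands as an observation only.

The compounds shown leave open whether the position stays equally silent in this assay when the phenyl carries no fluorine, when an amine or a methoxy group sits on it, or when a longer chain links the ring to the aromatic nitrogen. From the compounds shown here alone, the effect of the ethyl ester in compound 2 also remains open, since that compound differs from both compound 1 and compound 3 in more than one place.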